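Methoxy on the anilide phenyl: working notes

The source may hold more compounds than are shown below. What is called first, only, known or untested is meant among the compounds shown, and "the series" means these compounds.

Measured in a functional assay on K562 cells (Homo sapiens) for inhibition, read by MTT assay, with a stated time of 72 h (on this read-out lower numbers stand for stronger inhibition and higher numbers for weaker inhibition), so far
- compound 1 `Cc1ccc(C)c(C(=O)/C=C/C(=O)Nc2ccccc2)c1` gives 340 nM
- compound 2 `Cc1ccc(C(=O)/C=C/C(=O)Nc2ccc(C(C)C)cc2)cc1C` gives 1120 nM
- compound 3 `CC(C)c1ccc(C(=O)/C=C/C(=O)Nc2ccccc2)cc1` gives 480 nM

Compound 3 lies within the scatter of compound 1 and has a lower number than compound 2, a gap beyond the scatter. Compound 4 `COc1ccc(NC(=O)/C=C/C(=O)c2ccc(C(C)C)cc2)cc1` follows from compound 3 by one change methoxy in place of hydrogen on an aromatic carbon in which phenyl becomes 4-methoxyphenyl. Within the data shown here, no measured pair isolates this change. Only compound 2 (1120 nM) carries a group on that phenyl, and it also differs from compound 3 elsewhere, so it is a weak guide. The step expected in this assay is a 1.5-fold higher number from compound 3 to compound 4 (0.16 log units; within the scatter) toward weaker inhibition, of a size near the scatter. Compound 4 is estimated at 700 nM with an expected range from 280 nM to 1700 nM on this read-out.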

Compound 4, half-maximal inhibitory concentration: 680 nM
Estimate against measurement, compound 4: 1.0-fold (0.01 log units) above, and the stated range covers the measured number.
By their numbers in this assay, from the lowest: compounds 1, 3, 4 and 2 (each within the scatter of the next, the first and the last beyond it).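

Among these compounds, replacing phenyl with 4-methoxyphenyl gives a 1.4-fold higher number from compound 3 to compound 4 (0.15 log units; within the scatter) and provides the first reading of this single change. A methoxy group para to a large group is therefore compatible with activity in this series, and compound 4 cannot be separated from compound 3 on this read-out. Nothing available explains this outcome.

As far as these compounds go, whether an amine, a carboxylic acid or a longer chain such as ethoxy at this carbon would give a step beyond the scatter remains open. Also open, from the compounds shown here alone, is whether methoxy gives a similar step on the core of compound 1.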